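A few compounds are considered here, and "the series" means these few. Any claim that something is new, unique, unknown or untested is made for them only; others in the source may bear on it.

Measured so far in an ADME assay on KB cells (Homo sapiens) for cytotoxicity; a lower number here means that less compound is needed, a higher number that more compound is needed for the effect:
compound 1 `COC(=O)N1[C@@H]2C=C[C@@](OC)(C(=O)c3c2cc(OC)c(OC)c3OCc2ccc(OC)cc2)N1C(=O)OC`: > 300 ug/mL
compound 2 `COC(=O)N1[C@@H]2C=C[C@@](OC)(C(=O)c3c2cc(OC)c(OC)c3OCc2ccc(Cl)cc2)N1C(=O)OC`: 55.9 ug/mL
compound 3 `CCOC(=O)N1[C@@H]2C=C[C@@](OC)(C(=O)c3c2cc(OC)c(OC)c3OCc2ccc(Cl)cc2)N1C(=O)OCC`: 99.9 ug/mL

The value of compound 1 is a limit of this assay, not a number. Compound 2 and compound 1 differ by methoxy in place of chloro on an aromatic carbon. That change gives an at least 5.3-fold higher number from compound 2 to compound 1 (0.72 log units; beyond the scatter); the size of this step is known only as a lower bound due to the limit of > 300 ug/mL in this assay, at which 1 of the 3 values shown sits. Compound 3 carries the same chloro-bearing side chain as compound 2; how the two cores differ is not broken down here. In this assay compound 3 gives 99.9 ug/mL and compound 2 gives 55.9 ug/mL, two numbers within the usual scatter of each other.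

Compound 4 `CCOC(=O)N1[C@@H]2C=C[C@@](OC)(C(=O)c3c2cc(OC)c(OC)c3OCc2ccc(OC)cc2)N1C(=O)OCC` has not yet been measured. It differs from compound 3 by methoxy in place of chloro on an aromatic carbon, the same change, at the same place, as from compound 2 to compound 1. A step of a 4.5-fold higher number from compound 3 to compound 4 (0.65 log units; beyond the scatter) is expected, resting on compound 3 at 99.9 ug/mL and on the earlier step of an at least 5.3-fold higher number from compound 2 to compound 1 (0.72 log units; beyond the scatter). Compound 4 is therefore expected to give about 450 ug/mL, estimated between 150 ug/mL and 1200 ug/mL, and most probably only a limit of this assay.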

Compound 4, concentration for half-maximal effect: 63.1 ug/mL
The estimate for compound 4 lay 7.1-fold (0.85 log units) above the measured number; measured number below the stated range.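

In this assay, methoxy in place of chloro on an aromatic carbon gives a 1.6-fold lower number from compound 3 to compound 4 (0.20 log units; within the scatter), so on these two cores the change does not carry over as a step of one size: the same change on two cores in this assay, an at least 5.3-fold higher number (0.72 log units; beyond the scatter) from compound 2 to compound 1 and a 1.6-fold lower number (0.20 log units; within the scatter) from compound 3 to compound 4, at least 8.4-fold (0.92 log units) apart, beyond the scatter of two such steps. Compound 1 gives > 300 ug/mL, which is a limit of the assay and not a number, so the earlier step is known only as a lower bound: the limit of > 300 ug/mL in this assay, at which 1 of the 4 values shown sits. The two pairs show that the step differs between these cores, but they do not show which difference between the cores goes with this, or what the change would do on any further core.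

The compounds shown leave open whether fluoro, a nitrile or an amine at the same place on the benzyl side chain would behave like chloro or like methoxy on either core. Also open is how the change would behave on a core with a longer chain than those shown.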